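The source may hold more compounds than are shown below. What is called first, only, known or untested is meant among the compounds shown, and "the series" means these compounds.

Measured so far:
Compound 1, `Cc1cc(C)c(NC(=O)N(Cc2cccc(-c3cc[nH]n3)c2)C2CCCCC2)c(C)c1`; in a functional assay on a cell-free system (plasma) with sterol O-acyltransferase, Soat (Rattus norvegicus) as the target (on this read-out higher numbers stand for an effect only at larger amounts of compound and lower numbers for an effect already at smaller amounts), compound 1 gives 0.12 mg/kg.
Compound 2, `COc1ccc(CN(Cc2cccc(-c3cc[nH]n3)c2)C(=O)Nc2c(SC)cc(C)nc2SC)cc1`; in this assay compound 2 gives < 0.1 mg/kg.

The value for compound 2 is a limit of the assay and not a number. Where compound 2 stands is therefore known only as the limit of < 0.1 mg/kg in this assay, at which 1 of the 2 values shown sits. Compound 1, by contrast, has a measured number, and the two values sit close to one another.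

Compound 3, `COc1cccc(CN(Cc2cccc(-c3cc[nH]n3)c2)C(=O)Nc2c(SC)cc(C)nc2SC)c1`, is not yet measured. It differs from compound 2 by 3-methoxyphenyl in place of 4-methoxyphenyl on a saturated chain carbon bound to an amide-type nitrogen; the same atoms are present, joined differently, so the difference is one of where the methoxy group sits on the benzyl ring rather than of what is added or removed. For the measured compounds named here, no step between measured compounds describes such a change, so there is no direct guide to its size. The expectation is a step from compound 2 to compound 3 of an at least 1.2-fold higher number from compound 2 to compound 3 (0.07 log units; that floor lies within the scatter), that is, none beyond the usual scatter, with a slight lean toward the less potent side. Compound 3 is therefore expected at 0.12 mg/kg, with a range from 0.05 mg/kg to 0.4 mg/kg.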

Compound 3, dose for half-maximal effect: > 0.1 mg/kg
Compound 3: no number, only a limit; the forecaster's own chance of this, stated with the estimate: 35%; the middle value lies beyond the limit too.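

In this assay, for the compounds shown here, the change from 4-methoxybenzyl to 3-methoxybenzyl gives a number no lower from compound 2 to compound 3 (the limit leaves the size open) and is the only change so far that keeps the same atoms and moves one group. Compound 2 gives < 0.1 mg/kg here, which is a limit and not a number. Compound 3 gives > 0.1 mg/kg here, also a limit and not a number, so on this saturated chain carbon the 3-methoxyphenyl group shows no gain over the 4-methoxyphenyl group, while the size of the step cannot be read.

How far apart the two compounds lie stays open, and these values give no cause for the step. Also open, on these data alone, is what an amine, a carboxylic acid or a longer chain in place of the methoxy group would do on this benzyl ring.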